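The source may hold more compounds than are shown below. What is called first, only, known or untested is meant among the compounds shown, and "the series" means these compounds.

Series notes. Going by the values given here, in a functional assay on BXPC-3 cells (Homo sapiens) for antiproliferative activity, read by MTT assay, with a stated time of 24 h (on this read-out higher numbers stand for weaker inhibition and lower numbers for stronger inhibition), compound 2 `CCn1c(C(=O)NC2(CO)CC2)ccc1C(CC)(CC)c1ccc(OCS(=O)(=O)c2ccccc2)c(C)c1` gives 45400 nM, the highest of the three numbers so far: compound 1 `CCn1c(C(=O)N[C@@H](C)CO)ccc1C(CC)(CC)c1ccc(OCS(=O)(=O)c2ccccc2)c(C)c1` gives 15300 nM, and compound 3 `CCn1c(C(=O)N[C@H](CO)C(C)C)ccc1C(CC)(CC)c1ccc(OCS(=O)(=O)c2ccccc2)c(C)c1` gives 7720 nM. The steps at the amide substituent are modest: a 3.0-fold higher number from compound 1 to compound 2 (0.47 log units; beyond the scatter) and a 5.9-fold lower number from compound 2 to compound 3 (0.77 log units; beyond the scatter), whereas a 2.0-fold lower number from compound 1 to compound 3 (0.30 log units; within the scatter). Compound 4 `CCn1c(C(=O)NC2(C(=O)O)CC2)ccc1C(CC)(CC)c1ccc(OCS(=O)(=O)c2ccccc2)c(C)c1` differs from compound 2 by carboxy in place of hydroxymethyl on a saturated ring carbon. Among the compounds with values here, no measured pair shows this exchange, so the only guidance is that changes at this position have moved the number by modest amounts in either direction, with compound 2 already at the weak end. The expected outcome is a step of a 1.1-fold higher number from compound 2 to compound 4 (0.04 log units; within the scatter), possibly no more than the scatter. Compound 4 is therefore estimated at 50000 nM, with a range from 15000 nM to 150000 nM.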

Compound 4, half-maximal inhibitory concentration: > 50000 nM
Compound 4: a limit, no number; the forecaster's own chance of this, stated with the estimate: 25%; the middle value sits exactly at the limit.
By their numbers in this assay, from the lowest: compounds 3 and 1 (each within the scatter of the next); then compound 2. At a limit, above all of these: compound 4.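

In this assay compound 4 gives > 50000 nM, which is a limit of the assay and not a number. Carboxy in place of hydroxymethyl on the saturated ring carbon gives an at least 1.1-fold higher number from compound 2 to compound 4 (0.04 log units; that floor lies within the scatter), so that floor does not separate this exchange from the scatter. The 1-carboxycyclopropyl group nevertheless stands clear of the two open-chain amide substituents, with an at least 6.4-fold higher number from compound 3 to compound 4 (0.81 log units; beyond the scatter) and an at least 3.2-fold higher number from compound 1 to compound 4 (0.51 log units; beyond the scatter).

From the compounds shown here alone, how far the true value of compound 4 lies past the limit remains open. So does whether a methyl ester or an amine on the same ring carbon would track with hydroxymethyl or with carboxy.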